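Cyano for dimethylsulfamoyl on the benzyl ether of compound 2

This account rests on a few compounds, and the source may have more. Where it says the series, first, only, none or still open, it means among the compounds named here.

Measured compounds:
- compound 1 `C[C@@H]1CN(C(=O)OC(C)(C)C)CCN1c1ncc(OCC2CCN(S(C)(=O)=O)CC2)cn1`: 78 nM
- compound 2 `C[C@@H]1CN(C(=O)OC(C)(C)C)CCN1c1ncc(OCc2ccc(S(=O)(=O)N(C)C)cc2)cn1`: 264 nM

In a functional assay for agonist activity at Glucose-dependent insulinotropic receptor (Mus musculus), read by HTRF and cAMP accumulation, with a stated time of 45 min (a lower number here means that less compound is needed, a higher number that more compound is needed for the effect), compound 1 gives 78 nM. In this assay compound 2 gives 264 nM, the higher of the two numbers, and the gap to compound 1 lies beyond the usual scatter. Among the compounds with values here, the shared core of both carries a benzyl ether in compound 2 where compound 1 carries a methanesulfonyl piperidine methyl ether; no step between measured compounds isolates that exchange, so its two values are all that can be read from it.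

Compound 3 `C[C@@H]1CN(C(=O)OC(C)(C)C)CCN1c1ncc(OCc2ccc(C#N)cc2)cn1` is not yet measured. It differs from compound 2 in one place: cyano in place of dimethylsulfamoyl on an aromatic carbon. Within the data shown here, no measured pair shows this change, so the expectation rests on compound 2 alone. The step from compound 2 to compound 3 is expected to be small, a 1.1-fold higher number from compound 2 to compound 3 (0.06 log units; within the scatter), with no direction favored beyond the scatter. For compound 3 the estimate in this assay is 300 nM, between 100 nM and 900 nM.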

Compound 3, half-maximal effective concentration: 148 nM
Beside the measured number, compound 3's estimate is 2.0-fold (0.31 log units) above it; the range from low to high includes it.
By their numbers in this assay, from the lowest: compounds 1, 3 and 2 (each within the scatter of the next, the first and the last beyond it).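

In this assay, cyano in place of dimethylsulfamoyl on the aromatic carbon gives a 1.8-fold lower number from compound 2 to compound 3 (0.25 log units; within the scatter) and so shows that the sulfur-bearing group is not required at this position for a value in this range, even though cyano has fewer heavy atoms. The exchange of 1-(methylsulfonyl)piperidin-4-yl for 4-cyanophenyl gives a 1.9-fold higher number from compound 1 to compound 3 (0.28 log units; within the scatter) and so, unlike the earlier gap between the two sulfonyl-bearing compounds, leaves an aromatic ether that cannot be told apart from the piperidine ether of compound 1. Nothing available explains either step.

On these data alone, how a fluorine, a carboxylic acid or a primary amide would read at this same aromatic carbon remains open. So does whether a second nitrile at another ring carbon, or a longer chain between the ether oxygen and the ring, would leave the value within the same range.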